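Chloro for Fluoro on the Phenyl Ring: a Fourth Compound

The source may hold more compounds than are shown below. What is called first, only, known or untested is meant among the compounds shown, and "the series" means these compounds.

Measured so far in an ADME assay on Vero cells (Chlorocebus sabaeus) for cytotoxicity, read by neutral red uptake, tested at 25 ug/mL; a higher number here means a weaker effect of the compound at the concentration tested, a lower number a stronger effect:
Compound 1 `O=C1CSC(c2cccc(F)c2)N1CCN1CCCCC1` gives 100%.
Compound 2 `O=C1CSC(c2ccc(Cl)cc2)N1CCN1CCCCC1` gives 84%.
Compound 3 `O=C1CSC(c2ccc(F)cc2)N1CCN1CCCCC1` gives 100%.

Compound 3 stands level with compound 1, and the two share the highest number of the three; the step of no change at the digits printed from compound 1 to compound 3 (within the scatter) lies within the scatter. Against compound 2 the gap is real: a number 16 percentage points higher from compound 2 to compound 3 (beyond the scatter), a modest step beyond the scatter, and the same size is seen in a number 16 percentage points lower from compound 1 to compound 2 (beyond the scatter). Both times the compound carrying chloro on the phenyl ring returns the lower number in this assay.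

Compound 4 `O=C1CSC(c2ccccc2Cl)N1CCN1CCCCC1` is the next compound. It differs from compound 3 in one place: 2-chlorophenyl in place of 4-fluorophenyl on a saturated ring carbon. Two of the measured steps bear on this change: a number 16 percentage points higher from compound 2 to compound 3 (beyond the scatter) and a number 16 percentage points lower from compound 1 to compound 2 (beyond the scatter). Each of them exchanges a chloro-bearing phenyl for a fluoro-bearing one, or the reverse. Both were modest and pointed the same way, so a modest drop is expected here as well, of about a number 15 percentage points lower from compound 3 to compound 4 (beyond the scatter). Compound 4 is therefore estimated at 85% in this assay, with a likely range from 70% to 100%.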

Compound 4, a percentage reported as activity, at one concentration (the size of the read-out at that concentration, not a potency): 100%
Compound 4: the middle estimate sits 15 percentage points below what was measured; the measured number falls inside the stated range.
By their numbers in this assay, from the lowest: compound 2; then compounds 1, 3 and 4 (each within the scatter of the next).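

In this assay, among the compounds shown here, there is no change at the digits printed from compound 3 to compound 4 (within the scatter) and likewise no change at the digits printed from compound 1 to compound 4 (within the scatter), so a chloro on the phenyl ring does not by itself go with the lower number, as the earlier compounds had suggested. With the halogen kept and only its place on the phenyl ring changed, the reading is a number 16 percentage points higher from compound 2 to compound 4 (beyond the scatter) and this modest step beyond the scatter shows that 2-chlorophenyl and 4-chlorophenyl are not interchangeable on this saturated ring carbon, leaving compound 2 alone among the four with a lower number. Nothing available here accounts for the difference between the two chlorophenyl groups.

The compounds shown leave open where 3-chlorophenyl would fall, and whether a bromo, a methoxy or an amino group at any of these places on the phenyl ring would stay with compounds 1, 3 and 4 or join compound 2. They also leave open whether the same split between the two chlorophenyl groups would hold if the piperidine at the end of the shared side chain gave way to a morpholine or a longer chain.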